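The source may hold more compounds than are shown below. What is called first, only, known or untested is meant among the compounds shown, and "the series" means these compounds.

Measured so far:
- compound 1 `Nc1nnc(-c2ccccc2OCc2ccccc2)o1`: 85.2 mg/kg
- compound 2 `Nc1nnc(-c2ccccc2OCc2ccc(F)cc2)o1`: 2.5 mg/kg

In a functional assay on the whole organism with Mus musculus as the target (a lower number here means that less compound is needed, a higher number that more compound is needed for the effect), compound 2 gives 2.5 mg/kg, the lowest of the two numbers measured, while compound 1 gives 85.2 mg/kg. Among the measured compounds shown here, the only measured step is a 34-fold lower number from compound 1 to compound 2 (1.53 log units; beyond the scatter). The two compounds differ in one place, fluoro in place of hydrogen on an aromatic carbon, and the step lies far beyond the scatter.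

Compound 3 `Nc1nnc(-c2ccccc2OCc2ccc(Cl)cc2)o1` has not yet been measured. It differs from compound 2 by chloro in place of fluoro on an aromatic carbon. For the measured compounds named here, no measured step pairs fluoro against chloro at this place, so the step from compound 1 to compound 2 bears on it only indirectly: it shows that a halogen at this position is compatible with a low number, but it says nothing about how one halogen compares with another.

Given that, the expectation for compound 3 is a number close to that of compound 2, with a step of a 1.3-fold lower number from compound 2 to compound 3 (0.10 log units; within the scatter) that may not exceed the scatter. Compound 3 is estimated at 2 mg/kg, within a range from 0.5 mg/kg to 8 mg/kg.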

Compound 3, dose for half-maximal effect: > 100 mg/kg
Compound 3: a limit, no number (the forecaster's own chance of this, stated with the estimate: 5%); at least 50-fold (1.69 log units) between middle value and limit.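

In this assay compound 3 gives > 100 mg/kg as a limit of the assay and not as a number: the limit of > 100 mg/kg in this assay, at which 1 of the 3 values shown sits. Chloro in place of fluoro on this aromatic carbon, para to a large group, brings an at least 40-fold higher number from compound 2 to compound 3 (1.60 log units; beyond the scatter) and so shows that the low number of compound 2 does not extend to every halogen at this place. Chloro in place of hydrogen brings an at least 1.1-fold higher number from compound 1 to compound 3 (0.06 log units; that floor lies within the scatter) and so gives no sign of the drop seen with fluoro, which makes this position far more selective between the two halogens than the first step alone could show.

Going by these compounds, since compound 3 sits at a limit, how far its true number lies from that of compound 1 remains open, and the data give no reason for the gap between fluoro and chloro. On these data alone, it also remains open whether the low number belongs to fluoro alone, or whether a hydroxyl, a methoxy group, a nitrile or a methyl group at this same place would read like fluoro or like chloro.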